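The source may hold more compounds than are shown below. What is called first, only, known or untested is meant among the compounds shown, and "the series" means these compounds.

Of the compounds shown here, two built on a shared core have been tested in a functional assay on the whole organism (strain Swiss albino) for inhibition, with Mus musculus as the target, with a stated time of 0.5 h; on this read-out lower numbers stand for an effect already at smaller amounts and higher numbers for an effect only at larger amounts of compound. Compound 1 `Cc1ccccc1-n1c(Nc2nc(-c3ccc([N+](=O)[O-])cc3)cs2)n[nH]c1=S` gives 100 mg/kg. Compound 2 `Cc1ccc(-n2c(Nc3nc(-c4ccc(Cl)cc4)cs3)n[nH]c2=S)cc1` gives 300 mg/kg, the highest of the two numbers, and its gap from compound 1 lies beyond the usual scatter. Compound 3 `Cc1ccc(-n2c(Nc3nc(-c4ccc([N+](=O)[O-])cc4)cs3)n[nH]c2=S)cc1` differs from compound 2 in one place: nitro in place of chloro on an aromatic carbon. Among the measured compounds shown here, no measured pair shows this exact change, so the expectation for this assay leans on compound 1, which also carries the nitro group and gives 100 mg/kg. The step of a 2.0-fold lower number from compound 2 to compound 3 (0.30 log units; within the scatter) is expected to be a modest move toward a lower number. Compound 3 is therefore estimated at 150 mg/kg, within a range from 50 mg/kg to 400 mg/kg.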

Compound 3, minimum effective dose: 100 mg/kg
Compound 3: the middle estimate sits 1.5-fold (0.18 log units) above what was measured, within the range that was stated.
By their numbers in this assay, from the lowest: compounds 1 and 3 (each within the scatter of the next); then compound 2.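

In this assay, among the compounds shown here, nitro in place of chloro on this aromatic carbon gives a 3.0-fold lower number from compound 2 to compound 3 (0.48 log units; beyond the scatter) and is the first change at this position that can be read on its own. With nitro in place, 4-methylphenyl in place of 2-methylphenyl on the aromatic nitrogen gives no change at the digits printed from compound 1 to compound 3 (within the scatter) and so shows no difference beyond the scatter. Nothing available here explains either result. Still open, on these data alone, is whether nitro and chloro differ in the same way alongside 2-methylphenyl. An amine or a carboxylic acid in place of nitro on this carbon also remains untested among the compounds shown.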